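The compounds below may be only part of what the source reports. "The series", "measured", "known", "first", "only" and "open" are said of these compounds alone.

Measured compounds in a functional assay on PC-3 cells (Homo sapiens) for cytotoxicity, read by MTT assay, with a stated time of 72 h; a higher number here means a weaker inhibitor, a lower number a stronger inhibitor:
- compound 1, `COc1ccccc1Nc1nc(SCc2ccc(C(F)(F)F)cc2)nc2ccccc12`: 14100 nM
- compound 2, `Cc1ccccc1Nc1nc(SCc2ccc(C(F)(F)F)cc2)nc2ccccc12`: 36900 nM

Within the data shown here, compound 2 holds the highest of the two numbers in this assay; its only neighbour is compound 1, and the step between them, a 2.6-fold higher number from compound 1 to compound 2 (0.42 log units; beyond the scatter), is the single measured step. Compound 3, `O=[N+]([O-])c1cccc(Nc2nc(SCc3ccc(C(F)(F)F)cc3)nc3ccccc23)c1`, is not yet measured. It differs from compound 2 by 3-nitrophenyl in place of 2-methylphenyl on a nitrogen on an aromatic ring, so the whole aryl group on that nitrogen is exchanged rather than a single substituent swapped. Among the measured compounds shown here, the one measured step concerns the same aryl group, but it only traded methoxy for methyl on an aromatic carbon; nothing measured shows what a nitrophenyl group does here, nor what happens when the substituent moves within the ring. The expectation is therefore a step of no more than modest size, with direction unresolved; on balance a number near compound 2 is expected, a 1.5-fold lower number from compound 2 to compound 3 (0.17 log units; within the scatter). For compound 3 in this assay the estimate is 25000 nM, expected to fall between 6000 nM and 100000 nM.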

Compound 3, half-maximal inhibitory concentration: 13500 nM
The estimate for compound 3 lay 1.9-fold (0.27 log units) above the measured number, within the range that was stated.
By their numbers in this assay, from the lowest: compounds 3 and 1 (each within the scatter of the next); then compound 2.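

In this assay, the aryl group on this nitrogen can be exchanged whole with a measurable result: 3-nitrophenyl in place of 2-methylphenyl gives a 2.7-fold lower number from compound 2 to compound 3 (0.44 log units; beyond the scatter). Against the 2-methoxyphenyl group, the same 3-nitrophenyl group gives a 1.0-fold lower number from compound 1 to compound 3 (0.02 log units; within the scatter), so two quite different aryl groups read alike here and 2-methylphenyl alone stands apart among the three compounds. No measurement bears on the reason for this.

Compound 3 changes both the substituent and its place on the ring, so the shown compounds leave the two contributions unseparated, and 2-nitrophenyl or 3-methylphenyl on the same nitrogen would divide them. Also open, as far as these compounds go, is how the unsubstituted phenyl group, or a phenyl ring carrying an amine or a carboxylic acid, would read against these three values.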